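The compounds below may be only part of what the source reports. "The series", "measured", "known", "first", "only" and "open" are said of these compounds alone.

In a functional assay on HepG2 cells (Homo sapiens) for inhibition, read by MTT assay, with a stated time of 48 h (on this read-out higher numbers stand for weaker inhibition and lower numbers for stronger inhibition), three compounds built on a shared core have been measured: compound 1 `CCOC(=O)C1=C(N/N=C(/C#N)C(=O)OCC)Nc2[nH]nc(C)c2C1c1ccc(N(C)C)cc1` gives 46400 nM, compound 2 `CCOC(=O)C1=C(N/N=C(/Cl)c2ccc([N+](=O)[O-])cc2)Nc2[nH]nc(C)c2C1c1ccc(N(C)C)cc1` gives 55500 nM, and compound 3 `CCOC(=O)C1=C(N/C=N/c2ccc(C)cc2)Nc2[nH]nc(C)c2C1c1ccc(N(C)C)cc1` gives 44400 nM. Compound 3 thus stands level with the other two, inside the usual scatter of repeat measurements. Compound 4 `CCOC(=O)C1=C(N/N=C(/C(=O)Br)c2ccc(Cl)cc2)Nc2[nH]nc(C)c2C1c1ccc(N(C)C)cc1` differs from it on an amine nitrogen: a group of 12 heavy atoms (8 carbon, 1 nitrogen, 1 oxygen, 1 chlorine, 1 bromine; one six-membered aromatic ring of carbon only) in place of a group of 9 heavy atoms (8 carbon, 1 nitrogen; one six-membered aromatic ring of carbon only), on an amine nitrogen. The nearest guide is a swap at this same place: a 1.3-fold lower number from compound 2 to compound 3 (0.10 log units; within the scatter). The other two swaps, a 1.0-fold lower number from compound 1 to compound 3 (0.02 log units; within the scatter) and a 1.2-fold higher number from compound 1 to compound 2 (0.08 log units; within the scatter), also stay small. No step beyond the scatter is therefore expected in this assay, and the estimated change is a 1.0-fold higher number from compound 3 to compound 4 (0.01 log units; within the scatter). Compound 4 is expected at about 45000 nM, within a range from 18000 nM to 90000 nM.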

Compound 4, half-maximal inhibitory concentration: 50300 nM
The estimate for compound 4 lay 1.1-fold (0.05 log units) below the measured number; low and high end bracket the measured number.
By their numbers in this assay, from the lowest: compounds 3, 1, 4 and 2 (each within the scatter of the next).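

On the amine nitrogen of the shared core, a group holding a carbonyl, bromine and chlorine still leaves this assay level with the others: the steps are a 1.1-fold higher number from compound 3 to compound 4 (0.05 log units; within the scatter), a 1.1-fold lower number from compound 2 to compound 4 (0.04 log units; within the scatter) and a 1.1-fold higher number from compound 1 to compound 4 (0.04 log units; within the scatter). The read-out therefore stays level across four different groups at this place, now including one with 12 heavy atoms, whether or not the group holds an aromatic ring. Nothing available explains this lack of response. On these data alone, whether a carboxylic acid or a basic amine on this nitrogen would shift the number remains open.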